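The source may hold more compounds than are shown below. What is called first, only, known or untested is meant among the compounds shown, and "the series" means these compounds.

Working notes on the series.

Of the compounds shown here, two carry numbers so far. Compound 1 `Nc1ccc(C(=O)/C=C/c2ccc(O)c(F)c2)cc1-c1ccc(F)cc1` is assayed in a functional assay on SW480 cells (Homo sapiens) for cytotoxicity, read by sulforhodamine B assay, with a stated time of 48 h (on this read-out higher numbers stand for weaker inhibition and lower numbers for stronger inhibition), and gives 31700 nM. Compound 2 `COc1ccc(-c2cc(C(=O)/C=C/c3cccc(OC)c3OC)ccc2N)cc1OC`, which carries methoxy groups on both outer rings, gives in this assay a value of 8330 nM. For the measured compounds named here, of the two, compound 2 stands at the lower number, and the gap between compound 1 and compound 2 is beyond the scatter of repeats; with only two compounds measured, nothing more than this single comparison can be drawn.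

The next step goes from compound 2 to compound 3 `COc1ccc(/C=C/C(=O)c2ccc(N)c(-c3ccc(OC)c(OC)c3)c2)c(OC)c1`, the two having the same atoms joined differently. The change is 2,4-dimethoxyphenyl in place of 2,3-dimethoxyphenyl on a double-bonded chain carbon bound to a double-bonded chain carbon. Going by the values given here, no step of this kind has been measured, so the expectation rests on the single value of compound 2 alone. The rearrangement keeps both methoxy groups on the same ring and changes nothing else, so the expected step in this assay is a 1.0-fold lower number from compound 2 to compound 3 (0.02 log units; within the scatter), that is, none beyond the usual scatter. For compound 3 the estimated value in this assay is 8000 nM, with a likely range from 3000 nM to 22000 nM.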

Compound 3, half-maximal inhibitory concentration: 9300 nM
The estimate for compound 3 lay 1.2-fold (0.07 log units) below the measured number; the range from low to high includes it.
By their numbers in this assay, from the lowest: compounds 2 and 3 (each within the scatter of the next); then compound 1.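

The first step within the series concerns the dimethoxyphenyl on a double-bonded chain carbon bound to a double-bonded chain carbon. In this assay, 2,4-dimethoxyphenyl in place of 2,3-dimethoxyphenyl gives a 1.1-fold higher number from compound 2 to compound 3 (0.05 log units; within the scatter), so this assay does not separate these two arrangements of the methoxy groups at this place, at least with the rest of compound 2 held constant. No measurement on hand bears on the reason for this result, and the step is recorded here only as an observation.

This single pair does not show whether the same tolerance extends to substituents of a different kind on this ring, such as a carboxylic acid or a dimethylamino group in place of a methoxy group, since compound 1 differs from compound 2 and compound 3 in more than one place and cannot settle the matter. Also open, on these data alone, is how the values respond to changes on the other methoxy-bearing ring, which compound 2 and compound 3 share unchanged.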